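Moving a fluorine around a difluorophenyl ring

The compounds below may be only part of what the source reports. "The series", "measured", "known", "first", "only" and "open" are said of these compounds alone.

Measured so far:
compound 1 `Fc1cccc(Nc2nc3nonc3nc2Nc2ccccc2F)c1` gives 190 nM
compound 2 `Fc1ccc(Nc2nc3nonc3nc2Nc2ccccc2F)cc1` gives 2300 nM
compound 3 `Fc1ccccc1Nc1nc2nonc2nc1Nc1cccc(F)c1F` gives 500 nM

These values come from an assay on mitochondria from L6 cells (Rattus norvegicus) for activation, with a stated time of 90 min; a lower number here means that less compound is needed, a higher number that more compound is needed for the effect. Compound 3 sits second highest of the three: compound 1 lies a 2.6-fold higher number from compound 1 to compound 3 (0.42 log units; beyond the scatter) from it, and compound 2 lies a 4.6-fold lower number from compound 2 to compound 3 (0.66 log units; beyond the scatter) from it. Compound 4 `Fc1ccc(Nc2nc3nonc3nc2Nc2ccccc2F)c(F)c1` has not yet been tested in this assay. Compared with compound 3 it differs as follows: 2,4-difluorophenyl in place of 2,3-difluorophenyl on a nitrogen on an aromatic ring.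

Two measured steps speak to this change. Going from compound 1 to compound 2, a 4-fluorophenyl replaced a 3-fluorophenyl on the same nitrogen, and the result was a 12-fold higher number from compound 1 to compound 2 (1.08 log units; beyond the scatter). Going from compound 2 to compound 3 gave a 4.6-fold lower number from compound 2 to compound 3 (0.66 log units; beyond the scatter), and from compound 1 to compound 3 gave a 2.6-fold higher number from compound 1 to compound 3 (0.42 log units; beyond the scatter). The step from compound 3 to compound 4 repeats the 3-fluorophenyl to 4-fluorophenyl pattern on a ring that already carries a second fluorine, so the number is expected to rise in this assay, probably by a sizable step, though whether the second fluorine softens that is not known from three compounds.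

Compound 4 is therefore expected to show 3000 nM in this assay, within a range of 1000 nM to 10000 nM, an estimated step of a 6.0-fold higher number from compound 3 to compound 4 (0.78 log units; beyond the scatter).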

Compound 4, half-maximal effective concentration: 300 nM
The estimate for compound 4 lay 10-fold (1.00 log units) above the measured number, and the stated range ends above it.
By their numbers in this assay, from the lowest: compounds 1, 4 and 3 (each within the scatter of the next, the first and the last beyond it); then compound 2.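

In this assay, for the compounds shown here, exchanging 2,3-difluorophenyl for 2,4-difluorophenyl on the nitrogen gives a step that stays within the scatter, a 1.7-fold lower number from compound 3 to compound 4 (0.22 log units; within the scatter), and the comparison with the single fluorine of compound 1 also stays within it, a 1.6-fold higher number from compound 1 to compound 4 (0.20 log units; within the scatter). The large rise seen earlier with 4-fluorophenyl therefore does not carry over to 2,4-difluorophenyl: adding one more fluoro to the 4-fluorophenyl ring gives a 7.7-fold lower number from compound 2 to compound 4 (0.88 log units; beyond the scatter), so the number depends on the whole pattern of fluorines on this ring and not on one fluorine alone. Adding a fluoro also has no single effect at this place, since its direction and size depend on the ring that receives it: the same change on two cores in this assay, a 2.6-fold higher number (0.42 log units; beyond the scatter) from compound 1 to compound 3 and a 7.7-fold lower number (0.88 log units; beyond the scatter) from compound 2 to compound 4, 20-fold (1.30 log units) apart, beyond the scatter of two such steps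

The compounds shown carry only fluorine on this ring, so it remains open whether a chlorine, a methoxy group or a nitrile would follow the same pattern. As far as these compounds go, it also remains open where 3,4-difluorophenyl would fall, since that group combines the two single-fluorine patterns of compound 1 and compound 2.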